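This account rests on a few compounds, and the source may have more. Where it says the series, first, only, none or still open, it means among the compounds named here.

Measured so far: compound 1 `Nc1ccc(C(=O)/C=C/c2ccc(Cl)cc2)cc1` with 58%; compound 2 `Nc1ccc(C(=O)/C=C/c2ccco2)cc1` with 33%.

In a functional assay on the whole organism (strain albino) for inhibition, with Rattus norvegicus as the target, read by paw edema, with stated times of 30 min and 4 h, at a dose of 100 mg/kg by the oral route (on this read-out lower numbers stand for less inhibition and higher numbers for more inhibition at the one dose given (going by the name of the read-out)), compound 1 holds the higher of the two numbers, and compound 2 stands well below it, beyond the scatter. Compound 3 `CC(O[N+](=O)[O-])C(=O)Nc1ccc(C(=O)/C=C/c2ccc(Cl)cc2)cc1` has not been measured. It differs from compound 1 by a group of 8 heavy atoms (3 carbon, 1 nitrogen, 4 oxygen; no ring) in place of a hydrogen atom, on a nitrogen on an aromatic ring. Among the measured compounds shown here, no measured pair shows a change of this kind, so the data give no step to lean on. The expected step is a number 2 percentage points higher from compound 1 to compound 3 (within the scatter), a change within the scatter. Compound 3 is estimated at 60%, with a range from 40% to 78%.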

Compound 3, a percentage reported as inhibition, in the whole organism at one dose (the size of the read-out at that dose, not a potency): 61%
Estimate against measurement, compound 3: 1 percentage points below, within the range that was stated.
By their numbers in this assay, from the lowest: compound 2; then compounds 1 and 3 (each within the scatter of the next).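

In this assay, a group of 8 heavy atoms (3 carbon, 1 nitrogen, 4 oxygen; no ring) in place of a hydrogen atom, on a nitrogen on an aromatic ring, gives a number 3 percentage points higher from compound 1 to compound 3 (within the scatter). This position therefore accepts the group without the read-out telling the two compounds apart. No measurement given here speaks to why.

The compounds shown leave open whether an acetyl group on the same nitrogen would read like this group, and whether this group on the core of compound 2 would give a similar step.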